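Glycosylation of a Macrocyclic Alkaloid Core Against Resistant Leukaemia Cells

A few compounds are considered here, and "the series" means these few. Any claim that something is new, unique, unknown or untested is made for them only; others in the source may bear on it.

Compound 1 `O=C1CCN[C@@H](c2ccc(O)cc2)CCCN(C(=O)/C=C\c2ccccc2)CCCN1` — in a functional assay on K562/A02 cells (Homo sapiens) for cytotoxicity, read by MTT assay, with a stated time of 48 h (on this read-out lower numbers stand for stronger inhibition and higher numbers for weaker inhibition), compound 1 gives > 200000 nM, a limit of the assay rather than a number.
Compound 2 `C[C@@H]1O[C@@H](Oc2ccc([C@H]3CCCN(C(=O)/C=C/c4ccccc4)CCCNC(=O)CCN3)cc2)[C@H](O[C@@H]2O[C@H](COC(=O)c3ccccc3)[C@@H](O)[C@H](O)[C@H]2O)[C@H](O)[C@H]1O` — in this assay compound 2 gives > 200000 nM, again only a limit.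

Compound 1 therefore stands at the edge of what the assay can report; the other value shown is a limit as well, so (the limit of > 200000 nM in this assay, at which 2 of the 2 values shown sit), and no ordering between compound 1 and compound 2 can be read from these two entries. Among the measured compounds shown here, no step between measured compounds that differ in a single place is available.

Compound 3 `C[C@H]1O[C@@H](Oc2ccc([C@H]3CCCN(C(=O)/C=C\c4ccccc4)CCCNC(=O)CCN3)cc2)[C@@H](O)[C@@H](O)[C@@H]1O` is not yet measured. It differs from compound 1 by a group of 10 heavy atoms (6 carbon, 4 oxygen; one six-membered non-aromatic ring with 1 hetero atom) in place of a hydrogen atom, on an oxygen on an aromatic ring.

For the measured compounds named here, since both known values are limits, there is no measured step to anchor an expectation, and the change in this assay from compound 1 to compound 3 is expected to be none beyond the scatter, with direction unknown. For compound 3 the estimate is 200000 nM, spanning 50000 nM to 600000 nM, and the step this implies is a number no higher from compound 1 to compound 3 (the limit leaves the size open), most likely returned again as a limit.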

Compound 3, half-maximal inhibitory concentration: > 200000 nM
Compound 3: no number, only a limit; the forecaster's own chance of this, stated with the estimate: 75%; the middle value lies on the limit itself.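

In this assay compound 3 gives > 200000 nM as a limit of the assay and not a number. Among the compounds shown here, compound 1 also sits at a limit, so no step from compound 1 to compound 3 can be read: the limit of > 200000 nM in this assay, at which 3 of the 3 values shown sit. How strongly any of these compounds acts on these cells remains open, as does whether the added group changes that at all.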